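Fluoro and Chain Length in a Whole-Organism Series

The compounds below may be only part of what the source reports. "The series", "measured", "known", "first", "only" and "open" are said of these compounds alone.

Of the compounds shown here, three have been measured. In a functional assay on the whole organism with Scenedesmus acutus as the target, with a stated time of 20 h (on this read-out lower numbers stand for stronger inhibition and higher numbers for weaker inhibition), compound 1 `CCCOC(=O)c1cc(N2C(=O)C3=C(CCCC3)C2=O)c(F)cc1Cl` gives 66.1 nM. In this assay compound 2 `CCCOC(=O)c1cc(N2C(=O)C3=C(CCCC3)C2=O)ccc1Cl` gives 661 nM. In this assay compound 3 `CCCCOC(=O)c1cc(N2C(=O)C3=C(CCCC3)C2=O)ccc1Cl` gives 7760 nM.

Two changes connect them. The change fluoro in place of hydrogen on an aromatic carbon gave a 10-fold lower number from compound 2 to compound 1 (1.00 log units; beyond the scatter). The change methyl in place of hydrogen on a saturated chain carbon, three bonds along the chain from an oxygen next to a carbonyl group gave a 12-fold higher number from compound 2 to compound 3 (1.07 log units; beyond the scatter), leaving compound 3 with the highest number of the three.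

Compound 4 `CCCCOC(=O)c1cc(N2C(=O)C3=C(CCCC3)C2=O)c(F)cc1Cl` is not yet measured. It differs from compound 3 by fluoro in place of hydrogen on an aromatic carbon, the same kind of change as that from compound 2 to compound 1, though here the place is para to a butoxycarbonyl group rather than a propoxycarbonyl group. Compound 4 is expected to show a 7.8-fold lower number from compound 3 to compound 4 (0.89 log units; beyond the scatter), resting on the step of a 10-fold lower number from compound 2 to compound 1 (1.00 log units; beyond the scatter) seen for compound 1. Compound 4 is therefore estimated at 1000 nM, between 300 nM and 3500 nM.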

Compound 4, half-maximal inhibitory concentration: 141 nM
Beside the measured number, compound 4's estimate is 7.1-fold (0.85 log units) above it, and the stated range ends above it.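

In this assay, fluoro in place of hydrogen on an aromatic carbon again lowered the number, now with a 55-fold lower number from compound 3 to compound 4 (1.74 log units; beyond the scatter), but the size of the step did not carry over from one core to the other: the same change on two cores in this assay, a 10-fold lower number (1.00 log units; beyond the scatter) from compound 2 to compound 1 and a 55-fold lower number (1.74 log units; beyond the scatter) from compound 3 to compound 4, 5.5-fold (0.74 log units) apart, beyond the scatter of two such steps. The added methyl on the chain again raised the number, now with a 2.1-fold higher number from compound 1 to compound 4 (0.33 log units; beyond the scatter), and its size also differed between the cores: the same change on two cores in this assay, a 12-fold higher number (1.07 log units; beyond the scatter) from compound 2 to compound 3 and a 2.1-fold higher number (0.33 log units; beyond the scatter) from compound 1 to compound 4, 5.5-fold (0.74 log units) apart, beyond the scatter of two such steps. The direction of each change thus held in both pairs while the size did not, though four compounds cannot show why, or whether this holds beyond them.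

The compounds shown leave open whether a bromo group in place of the fluoro would follow the same course. They also leave open how a longer chain on the ester would behave, with or without the fluoro.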